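A few compounds are considered here, and "the series" means these few. Any claim that something is new, unique, unknown or untested is made for them only; others in the source may bear on it.

Compound 1 `Cc1cn([C@@H]2O[C@H](CO)[C@@H](CN)[C@@H]2O)c(=O)[nH]c1=O`: in a functional assay on P388 cells (Mus musculus) for antiproliferative activity, with a stated time of 72 h (on this read-out higher numbers stand for an effect only at larger amounts of compound and lower numbers for an effect already at smaller amounts), compound 1 gives > 100 uM, a limit of the assay.
Compound 2 `Cc1cn([C@H]2C[C@H](CF)[C@@H](CO)O2)c(=O)[nH]c1=O`: compound 2 gives > 100 uM, likewise a limit.
Compound 3 `Cc1cn([C@@H]2O[C@H](CO)[C@@H](CN=[N+]=[N-])[C@@H]2O)c(=O)[nH]c1=O`: compound 3 gives > 100 uM, again a limit.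

Compound 3 thus stands at the limit of > 100 uM in this assay, at which 3 of the 3 values shown sit, alongside compound 1 and compound 2. Among the measured compounds shown here, the single step connecting measured compounds, a step that the two limits leave unreadable from compound 1 to compound 3, is consequently unreadable, and the series yields no usable size of step. Compound 4 `Cc1cn([C@@H]2O[C@H](CO)[C@@H](CF)[C@@H]2O)c(=O)[nH]c1=O` differs from compound 3 by fluoro in place of azido on a saturated chain carbon bound to a saturated ring carbon. For the measured compounds named here, no measured step bears on this change; compound 2 carries the same fluoromethyl group and sits at the limit, but no step to it is defined. The expectation for compound 4 is therefore another limit rather than a number, with a step that the limit leaves unreadable from compound 3 to compound 4 expected to stay within the scatter. Compound 4 is estimated at 150 uM, in the range 50 uM to 500 uM.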

Compound 4, concentration for half-maximal effect: > 100 uM
Compound 4 gave a limit, no number; the forecaster's own chance of this, stated with the estimate: 75%; the middle value is on the limit's open side.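

No step from compound 1, compound 2 or compound 3 to compound 4 can be read, as all four compounds sit at one limit: the limit of > 100 uM in this assay, at which 4 of the 4 values shown sit.

The compounds shown leave open how large any of these changes is, and what structure would give a number rather than a limit.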